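A few compounds are considered here, and "the series" means these few. Any claim that something is new, unique, unknown or untested is made for them only; others in the source may bear on it.

In a functional assay on HeLa cells (Homo sapiens) for antiproliferative activity, read by MTT assay, with a stated time of 72 h (a higher number here means a weaker inhibitor, a lower number a stronger inhibitor), compound 1 (`NC(=S)N/N=C/c1ccccc1O`) gives >= 5000 nM as a limit of the assay and not as a number. Compound 2 (`COc1cccc(/C=N/NC(=S)Nc2ccccc2)c1O`) gives 1700 nM in this assay as a true number, but it differs from compound 1 in more than one place, so no single change can be read from the pair. Compound 3 (`CCN(CC)c1ccc(/C=N/NC(N)=S)c(O)c1`) is compound 1 with diethylamino in place of hydrogen on an aromatic carbon, meta to a hydroxy group (diethylamino in place of hydrogen on an aromatic carbon). Going by the values given here, no measured step shows what such a change does, so any forecast here is loose. Among the compounds with values here, the only hint is that compound 2 reaches 1700 nM as a measured value. A moderate gain toward stronger inhibition is expected, with an estimated step of an at least 2.0-fold lower number from compound 1 to compound 3 (0.30 log units; that floor lies within the scatter) in this assay and a real chance of no gain beyond the scatter. In this assay compound 3 is estimated at 2500 nM with 500 nM to 12000 nM as the expected range.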

Compound 3, half-maximal inhibitory concentration: 2000 nM
Beside the measured number, compound 3's estimate is 1.3-fold (0.10 log units) above it, within the range that was stated.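

Going by these compounds alone, until now no pair of compounds isolated a single change, and this pair gives the first one. In this assay, putting diethylamino in place of hydrogen on the aromatic carbon meta to a hydroxy group and para to a group of 6 heavy atoms gives an at least 2.5-fold lower number from compound 1 to compound 3 (0.39 log units; beyond the scatter), so this position accepts the added group and the number drops beyond the scatter. Compound 1 stands at a limit of the assay and not at a number, so the step gives only a smallest size, and its true size stays unknown: the limit of >= 5000 nM in this assay, at which 1 of the 3 values shown sits.

Going by these compounds, with a single group at this position, it remains open whether the gain is particular to diethylamino or would also come with dimethylamino or a carboxylic acid on the same carbon. On these data alone, it is equally open whether diethylamino would act the same way on another carbon of the ring.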